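A bromobenzyl swap on a weak inhibitor

The source may hold more compounds than are shown below. What is called first, only, known or untested is meant among the compounds shown, and "the series" means these compounds.

a functional assay on a cell-free system (plasma, Oryctolagus cuniculus) for inhibition, with stated times of 5 min, 1 min and 6 min (a lower number here means a stronger inhibitor, a higher number a weaker inhibitor), gave these values:
Compound 1 (`CCOC(=O)c1[nH]c(-c2cccc(C#N)c2)nc1C`) gives > 30000 nM (a limit of the assay)
Compound 2 (`CCOC(=O)c1c(C)nc(-c2cccc(C#N)c2)n1OCc1ccncc1`) gives 6200 nM (a measured number)
Compound 3 (`CCOC(=O)c1c(C)nc(-c2cccc(C#N)c2)n1OCc1cccc(Cl)c1`) gives 19400 nM (a measured number)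

Compound 3 at 19400 nM is the higher of the two numbers, and compound 2 at 6200 nM lies nearest to it. Compound 4 (`CCOC(=O)c1c(C)nc(-c2cccc(C#N)c2)n1OCc1ccc(Br)cc1`) carries 4-bromophenyl in place of 3-chlorophenyl on a saturated chain carbon bound to an oxygen on an aromatic ring. The closest measured change (a 3.1-fold higher number from compound 2 to compound 3 (0.50 log units; beyond the scatter)) exchanged pyridin-4-yl for 3-chlorophenyl at that place, and the other (an at least 1.5-fold lower number from compound 1 to compound 3 (0.18 log units; that floor lies within the scatter)) gives only a floor. Neither exchanges one such phenyl for another, so in this assay no step beyond the scatter is expected. The estimated change stays within that scatter (a 1.1-fold lower number from compound 3 to compound 4 (0.06 log units; within the scatter)). The expected value for compound 4 is 17000 nM (estimated range 6000 nM to 30000 nM).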

Compound 4, half-maximal inhibitory concentration: 24600 nM
Compound 4: middle estimate off by 1.4-fold (0.16 log units), on the low side, within the range that was stated.
By their numbers in this assay, from the lowest: compound 2; then compounds 3 and 4 (each within the scatter of the next). At a limit, above all of these: compound 1.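

In this assay, exchanging 3-chlorophenyl for 4-bromophenyl on a saturated chain carbon bound to an oxygen on an aromatic ring gives a step within the scatter (a 1.3-fold higher number from compound 3 to compound 4 (0.10 log units; within the scatter)). Against pyridin-4-yl, 4-bromophenyl gives a step beyond the scatter (a 4.0-fold higher number from compound 2 to compound 4 (0.60 log units; beyond the scatter)), so both phenyl groups shown give higher numbers than pyridin-4-yl. The comparison with hydrogen on the aromatic nitrogen yields only a floor (an at least 1.2-fold lower number from compound 1 to compound 4 (0.08 log units; that floor lies within the scatter)): the limit of > 30000 nM in this assay, at which 1 of the 4 values shown sits. Open, going by these compounds, is whether the lower number of compound 2 depends on where the pyridine nitrogen sits, which a pyridin-3-yl group or a 4-aminophenyl group at this place would address.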